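Amide aryl group and inhibition in the chalcone series

The compounds below may be only part of what the source reports. "The series", "measured", "known", "first", "only" and "open" are said of these compounds alone.

Measured compounds:
compound 1, `COc1cc(/C=C/C(=O)c2cccc(NC(=O)c3ccco3)c2)ccc1O`, 82%
compound 2, `COc1cc(/C=C/C(=O)c2cccc(NC(=O)c3ccc(Cl)c(Cl)c3)c2)ccc1O`, 5%

Both were run in a functional assay on HUVEC cells (Homo sapiens) for inhibition, tested at 5 ug/mL; a lower number here means a weaker effect, a higher number a stronger effect of the compound at the concentration tested. Going by the values given here, compound 2 stands lowest of the two measured numbers; its only neighbour is compound 1, and the single step that separates them, a number 77 percentage points lower from compound 1 to compound 2 (beyond the scatter), shows that the group on the amide carbonyl carbon governs the read-out strongly.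

Compound 3, `COc1cc(/C=C/C(=O)c2cccc(NC(=O)c3ccccc3)c2)ccc1O`, has not been measured. Its difference from compound 2 is phenyl in place of 3,4-dichlorophenyl on a carbonyl carbon. Among the compounds with values here, no measured step exchanges 3,4-dichlorophenyl for phenyl, so only the large step from compound 1 to compound 2 is informative, and it says the aryl group matters without saying what a plain phenyl does. A step upward is expected for compound 3, estimated at a number 35 percentage points higher from compound 2 to compound 3 (beyond the scatter), with wide uncertainty. In this assay compound 3 is therefore expected to give about 40%, between 10% and 75%.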

Compound 3, a percentage reported as inhibition, at one concentration (the size of the read-out at that concentration, not a potency): 48%
Beside the measured number, compound 3's estimate is 8 percentage points below it; low and high end bracket the measured number.
By their numbers in this assay, from the lowest: compound 2; then compound 3; then compound 1.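

In this assay, the two chlorine atoms on their own carry a large part of the difference seen so far: with the ring kept and only the chlorines gone, the result is a number 43 percentage points higher from compound 2 to compound 3 (beyond the scatter). The ring itself also counts, as exchanging furan-2-yl for phenyl on the same carbonyl carbon gives a number 34 percentage points lower from compound 1 to compound 3 (beyond the scatter), so both changes move the read-out and the order furan-2-yl, phenyl, 3,4-dichlorophenyl holds for these three compounds only. No measurement to hand offers a reason for either step.

Still open, from the compounds shown here alone, is whether a single chlorine atom on the phenyl ring gives a read-out nearer to that of compound 2 or of compound 3. Going by these compounds, it is also open whether thiophen-2-yl or pyridin-3-yl on this carbonyl carbon stays close to compound 1.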